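The source may hold more compounds than are shown below. What is called first, only, known or untested is meant among the compounds shown, and "the series" means these compounds.

Compound 3 `Cc1ccc(-c2nn(-c3ccccc3)cc2C(=O)NOCc2ccccc2Cl)cc1` gives 2640 nM in a functional assay on MCF7 cells (Homo sapiens) for antiproliferative activity, read by MTT assay, with a stated time of 48 h, in the presence of a further agent that is not named here; a higher number here means a weaker inhibitor of growth, a lower number a stronger inhibitor of growth; its number sits at the top of the three measured, but the distances to compound 2 `Cc1ccc(-c2nn(-c3ccccc3)cc2C(=O)NOCc2ccccc2F)cc1` at 2110 nM and to compound 1 `Cc1ccc(-c2nn(-c3ccccc3)cc2C(=O)NOCc2ccccc2)cc1` at 1870 nM are within the scatter. Compound 4 `Cc1ccc(-c2nn(-c3ccccc3)cc2C(=O)NOCc2ccc(Cl)cc2Cl)cc1` differs from compound 3 by chloro in place of hydrogen on an aromatic carbon. The measured steps that bear on this change are a 1.4-fold higher number from compound 1 to compound 3 (0.15 log units; within the scatter) and a 1.1-fold higher number from compound 1 to compound 2 (0.05 log units; within the scatter), each a halogen in place of hydrogen, together with a 1.3-fold higher number from compound 2 to compound 3 (0.10 log units; within the scatter); none of them moved beyond the scatter. A further chloro is therefore expected to bring only a small shift upward, if any, a 1.1-fold higher number from compound 3 to compound 4 (0.06 log units; within the scatter), nothing beyond the scatter. For compound 4 the estimate in this assay is 3000 nM, within a range from 1500 nM to 6000 nM.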

Compound 4, concentration for 50% growth inhibition: 2310 nM
Compound 4: the middle estimate sits 1.3-fold (0.11 log units) above what was measured, within the range that was stated.
By their numbers in this assay, from the lowest: compounds 1, 2, 4 and 3 (each within the scatter of the next).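

Adding a chloro para to a large group and meta to a chloro group, which turns 2-chlorobenzyl into 2,4-dichlorobenzyl, gives a 1.1-fold lower number from compound 3 to compound 4 (0.06 log units; within the scatter) in this assay. A second halogen on this ring therefore leaves the number as flat as a single one did, and the comparisons with the other two compounds agree: a 1.1-fold higher number from compound 2 to compound 4 (0.04 log units; within the scatter) and a 1.2-fold higher number from compound 1 to compound 4 (0.09 log units; within the scatter). Nothing available here gives a cause for this flat response. On these data alone, what an amine or a carboxylic acid would do at this place stays open, as does a longer chain in place of the benzyl group.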